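The compounds below may be only part of what the source reports. "The series", "measured", "known", "first", "only" and "open" are said of these compounds alone.

Compound 1 `CCCc1c(Cl)c(O)c(Cl)c(OC)c1Oc1c(Cl)c(O)c(Cl)c2c1C(=O)O[C@@H]2CC`: > 100000 nM
Compound 2 `CCCc1c(Cl)c(O)cc(O)c1Oc1c(Cl)c(O)c(Cl)c2c1C(=O)O[C@@H]2CC`: > 50000 nM

In an ADME assay on MDCK cells (Canis lupus familiaris) for cytotoxicity, read by CellTiter-Glo, with a stated time of 40 h (a lower number here means that less compound is tolerated, a higher number that more compound is tolerated), compound 2 gives > 50000 nM, which is a limit of the assay rather than a measured number, so compound 2 sits at the limit of > 50000 nM in this assay, at which 1 of the 2 values shown sits. Compound 1 gives > 100000 nM, also a limit, sitting at the limit of > 100000 nM in this assay, at which 1 of the 2 values shown sits. Among the compounds with values here, both compounds are therefore tolerated up to the highest concentration tested, and no measured step between them can be drawn.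

Compound 3 `CCCc1c(Cl)c(O)cc(OC)c1Oc1c(Cl)c(O)c(Cl)c2c1C(=O)O[C@@H]2CC` differs from compound 2 by methyl in place of hydrogen on an oxygen on an aromatic ring. For this assay the step that the limit leaves unreadable from compound 2 to compound 3 is expected to stay within the usual scatter, with no real change in either direction. Compound 3 is estimated at 100000 nM, with a range from 50000 nM to 300000 nM, and most likely again reported only as a limit.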

Compound 3, half-maximal cytotoxic concentration: > 100000 nM
Compound 3 gave a limit, no number; the forecaster's own chance of this, stated with the estimate: 85%; the middle value sits exactly at the limit.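

In this assay, within the data shown here, compound 1, compound 2 and compound 3 all give limits rather than numbers, so no step among them can be read. On these data alone, whether hydroxy to methoxy, or hydrogen in place of chloro, changes cytotoxicity remains open.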